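A few compounds are considered here, and "the series" means these few. Any claim that something is new, unique, unknown or untested is made for them only; others in the source may bear on it.

Compound 1 `COc1cc(OC)c(/C=C/S(=O)(=O)Nc2ccc(OC)c(O)c2)c(OC)c1`: 15 nM
Compound 2 `COc1cc(OC)c(/C=C/S(=O)(=O)Nc2ccc(OC)c(NCC(=O)O)c2)c(OC)c1`: 20 nM

Both compounds were tested in a functional assay on K562 cells (Homo sapiens) for cytotoxicity, read by trypan blue exclusion, with a stated time of 96 h; on this read-out higher numbers stand for weaker inhibition and lower numbers for stronger inhibition. Compound 2, at 20 nM, lies within the scatter of compound 1, so the two cannot be ranked. Compound 3 `COc1cc(OC)c(/C=C/S(=O)(=O)Nc2ccc(OC)c(NC(C(=O)O)c3ccc(Br)cc3)c2)c(OC)c1` differs from compound 2 at one spot: 4-bromophenyl in place of hydrogen on a saturated chain carbon bound to a carbonyl carbon and a nitrogen on an aromatic ring. Among the compounds with values here, only one measured step bears on this change, a 1.3-fold higher number from compound 1 to compound 2 (0.12 log units; within the scatter). It shows that replacing the group on that aromatic carbon left the number within the scatter. It bears only indirectly, as neither measured compound carries an added ring on the chain. A modest step towards a higher number is therefore expected, with wide uncertainty, and the estimated change is a 1.8-fold higher number from compound 2 to compound 3 (0.24 log units; within the scatter). Compound 3 is expected at about 35 nM, with an estimated range of 10 nM to 150 nM.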

Compound 3, half-maximal inhibitory concentration: 75 nM
Compound 3: the middle estimate sits 2.1-fold (0.33 log units) below what was measured, and the stated range covers the measured number.
By their numbers in this assay, from the lowest: compounds 1 and 2 (each within the scatter of the next); then compound 3.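

Within this assay, the chain carbon of the (carboxymethyl)amino group does respond to substitution: 4-bromophenyl in place of hydrogen there gives a step beyond the scatter (a 3.8-fold higher number from compound 2 to compound 3 (0.57 log units; beyond the scatter)), whereas the earlier change on the aromatic carbon stayed within it. Set against the hydroxy group of compound 1, the full ((4-bromophenyl)(carboxy)methyl)amino group also gives a step beyond the scatter (a 5.0-fold higher number from compound 1 to compound 3 (0.70 log units; beyond the scatter)). Nothing at hand explains this rise.

The compounds shown leave open whether the step comes from the ring or from its bromine, which phenyl or 4-chlorophenyl on the same carbon could separate. They also leave open how a small methyl group would behave there, and whether a methyl ester or an amide could stand in for the carboxylic acid.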